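The source may report more compounds than this note shows. Statements on the series, on what has been measured and on what is new or still open speak of the compounds shown alone.

Compound 1 `CNCc1c(OC)cc(Oc2cccc(Nc3ccccc3)c2)cc1OC`: 7430 nM
Compound 2 `COc1ccc([C@@H](C)NCc2c(OC)cc(Oc3cccc(Nc4ccccc4)c3)c(OC)c2OC)cc1`: 1630 nM

Of the compounds shown here, two have been measured in a functional assay on HT-29 cells (Homo sapiens) for inhibition, read by MTT assay, with a stated time of 72 h; on this read-out higher numbers stand for weaker inhibition and lower numbers for stronger inhibition. Compound 1 gives 7430 nM, the higher of the two numbers, while compound 2 gives 1630 nM, a lower number that lies beyond the usual scatter of this assay. For the measured compounds named here, no single-point step between the two measured compounds is available, so the gap between them can only be read as what the two values show.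

Compound 3 `COc1ccc(CCCNCc2c(OC)cc(Oc3cccc(Nc4ccccc4)c3)cc2OC)cc1` has not yet been measured. It is built from compound 1 by the change (2-(4-methoxyphenyl)ethyl in place of hydrogen on a saturated chain carbon bound to an amine nitrogen); in other words, a 2-(4-methoxyphenyl)ethyl takes the place of a hydrogen on a saturated chain carbon bound to an amine nitrogen, so that the methylamino of compound 1 becomes a (3-(4-methoxyphenyl)propyl)amino.

For compound 3 the expectation is a step of a 3.0-fold lower number from compound 1 to compound 3 (0.47 log units; beyond the scatter) towards a lower number, of moderate size, because compound 2, which also carries a larger group on the shared core, gives 1630 nM. Compound 3 is therefore estimated at 2500 nM, with a likely range from 900 nM to 7000 nM.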

Compound 3, half-maximal inhibitory concentration: 3320 nM
Estimate against measurement, compound 3: 1.3-fold (0.12 log units) below, within the range that was stated.
By their numbers in this assay, from the lowest: compound 2; then compound 3; then compound 1.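

In this assay, for the compounds shown here, the change from methylamino to (3-(4-methoxyphenyl)propyl)amino gives a 2.2-fold lower number from compound 1 to compound 3 (0.35 log units; beyond the scatter) and is the first change here that can be read in one place alone. It shows that this saturated chain carbon bound to an amine nitrogen can carry a 2-(4-methoxyphenyl)ethyl, a group of 10 heavy atoms with an aromatic ring, and that the number falls rather than rises when it does. This is one modest step from a single pair of compounds, so it marks no trend, and nothing measured here explains why the number falls.

From the compounds shown here alone, it remains open whether the step belongs to the chain, the aromatic ring or the methoxy, which a plain 3-phenylpropyl or a longer 4-(4-methoxyphenyl)butyl on the same amine could help to separate. Also open, going by these compounds, is whether the same position would give a similar step with a carboxylic acid or a second amine at the end of the chain.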